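Replacing the amino group on the ring nitrogen of compound 2

This account rests on a few compounds, and the source may have more. Where it says the series, first, only, none or still open, it means among the compounds named here.

Of the compounds shown here, three have been measured in an assay on isolated protein for inhibition of Indoleamine 2,3-dioxygenase 1 (Homo sapiens), read by fluorescence, with a stated time of 60 min; on this read-out higher numbers stand for weaker inhibition and lower numbers for stronger inhibition. Compound 1 `CS(=O)(=O)NNc1nonc1/C(=N/O)Nc1ccc(F)c(Br)c1` gives 609 nM, compound 2 `NNc1nonc1/C(=N/O)Nc1ccc(F)c(Br)c1` gives 108 nM, and compound 3 `CN(C)S(=O)(=O)CCCNc1nonc1/C(=N/O)Nc1ccc(F)c(Br)c1` gives 97 nM. Compound 2 thus stands second highest of the three numbers; compound 3 is nearest to it, the gap being within the scatter, and compound 1 is furthest. Of the steps, a 5.6-fold lower number from compound 1 to compound 2 (0.75 log units; beyond the scatter) came with hydrogen in place of methylsulfonyl on an amine nitrogen, and a 6.3-fold lower number from compound 1 to compound 3 (0.80 log units; beyond the scatter) with 3-(dimethylsulfamoyl)propyl in place of methanesulfonamido on a nitrogen on an aromatic ring, while a 1.1-fold lower number from compound 2 to compound 3 (0.05 log units; within the scatter) for 3-(dimethylsulfamoyl)propyl in place of amino on a nitrogen on an aromatic ring stayed within the scatter.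

Compound 4 `NS(=O)(=O)CCONc1nonc1/C(=N/O)Nc1ccc(F)c(Br)c1` is not yet measured. It differs from compound 2 as follows: 2-sulfamoylethoxy in place of amino on a nitrogen on an aromatic ring. Among the measured compounds shown here, the closest precedent is a 1.1-fold lower number from compound 2 to compound 3 (0.05 log units; within the scatter), where a sulfur-bearing chain on the same nitrogen left the number within the scatter. From compound 2 the step expected is a 1.1-fold higher number from compound 2 to compound 4 (0.05 log units; within the scatter), within the scatter. Compound 4 is therefore estimated to give about 120 nM in this assay, with a range of 45 nM to 320 nM.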

Compound 4, half-maximal inhibitory concentration: 87 nM
For compound 4 the middle estimate is 1.4-fold (0.14 log units) above the measured one; the measured number falls inside the stated range.
By their numbers in this assay, from the lowest: compounds 4, 3 and 2 (each within the scatter of the next); then compound 1.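

In this assay, 2-sulfamoylethoxy in place of amino on this nitrogen gives a 1.2-fold lower number from compound 2 to compound 4 (0.09 log units; within the scatter), so this position takes a second sulfur-bearing chain, here attached through oxygen, without a step beyond the scatter. The two chains also stand level, at a 1.1-fold lower number from compound 3 to compound 4 (0.05 log units; within the scatter), although they differ in more than one respect. Methanesulfonamido remains the one group that stands apart, with a 7.0-fold lower number from compound 1 to compound 4 (0.85 log units; beyond the scatter), so compound 1 goes against an otherwise flat picture across these four compounds.

No evidence at hand accounts for the flatness or for the gap to compound 1. Going by these compounds, it remains open whether a tertiary amine, a carboxylic acid or a longer chain on this nitrogen would stay level with compound 2.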